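Working notes: chloro added to the phenyl of compound 1

The compounds below may be only part of what the source reports. "The series", "measured", "known", "first", "only" and "open" are said of these compounds alone.

- compound 1 `Clc1cnc(Nc2cn[nH]c2)nc1Nc1ccccc1` gives 3660 nM
- compound 2 `COc1ccc(Nc2nc(Nc3cn[nH]c3)ncc2Cl)cc1` gives "not determined" (no result reported)

Among the measured compounds shown here, in a functional assay on MCF7 cells (Homo sapiens) for antiproliferative activity, read by MTT assay, with a stated time of 48 h (on this read-out higher numbers stand for weaker inhibition and lower numbers for stronger inhibition), compound 1 gives 3660 nM as the only number so far, so it cannot be ranked against another compound. Compound 3 `Clc1ccccc1Nc1nc(Nc2cn[nH]c2)ncc1Cl` differs from compound 1 by chloro in place of hydrogen on an aromatic carbon, ortho to a large group, taking phenyl to 2-chlorophenyl chloro in place of hydrogen on an aromatic carbon in the structure. For the measured compounds named here, no measured step is available to size this change, so no shift beyond the scatter is expected in this assay. The expected 1.2-fold lower number from compound 1 to compound 3 (0.09 log units; within the scatter) is therefore small. For compound 3 the estimated value is 3000 nM (1000 nM to 9000 nM).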

Compound 3, half-maximal inhibitory concentration: 1100 nM
For compound 3 the middle estimate is 2.7-fold (0.44 log units) above the measured one; measured number inside the range.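

In this assay, among the compounds shown here, chloro in place of hydrogen on an aromatic carbon, ortho to a large group, gives a 3.3-fold lower number from compound 1 to compound 3 (0.52 log units; beyond the scatter) and is the first measured sign that this phenyl tolerates substitution at this position. The entering group is a single heavy atom with no hydrogen-bond donors or acceptors, yet the step lies beyond the scatter. No available evidence bears on the reason for this step.

The step to compound 2 cannot be read. From the compounds shown here alone, whether fluoro, methyl or an amine at this same position would give a step of similar size stays open.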